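Adding a Third Methoxy Group to a Dimethoxy Compound

The source may hold more compounds than are shown below. What is called first, only, known or untested is meant among the compounds shown, and "the series" means these compounds.

Compound 1 `COc1cccc(C2CC(c3ccc4ccccc4c3O)=NN2)c1` carries a single methoxy group on one of its aromatic rings, and compound 3 `COc1cc(OC)cc(C2CC(c3ccc4ccccc4c3O)=NN2)c1` carries two. In a functional assay on HCT-116 cells (Homo sapiens) for cytotoxicity, read by crystal violet staining and colony formation, with a stated time of 7 days (on this read-out lower numbers stand for stronger inhibition and higher numbers for weaker inhibition), compound 1 gives 20800 nM, while compound 3 gives 4700 nM. The change between them is methoxy in place of hydrogen on an aromatic carbon, and it made a 4.4-fold lower number from compound 1 to compound 3 (0.65 log units; beyond the scatter).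

Compound 2 `COc1ccc(C2CC(c3ccc4ccccc4c3O)=NN2)c(OC)c1` also has two methoxy groups, but arranged differently; how its core differs from that of compound 1 is not broken down here. In this assay compound 2 gives 8800 nM.

Compound 4 `COc1ccc(C2CC(c3ccc4ccccc4c3O)=NN2)c(OC)c1OC` is compound 2 with the same kind of change, (methoxy in place of hydrogen on an aromatic carbon). The surroundings differ: in compound 3 the new methoxy sits meta to a large group and meta to a methoxy group, whereas in compound 4 it sits ortho to two methoxy groups and meta to a large group. Because the earlier step was a 4.4-fold lower number from compound 1 to compound 3 (0.65 log units; beyond the scatter), compound 4 is expected to show a 2.5-fold lower number from compound 2 to compound 4 (0.40 log units; beyond the scatter) in this assay, a somewhat smaller step given the crowded place. The estimate for compound 4 is 3500 nM, with a likely range from 1200 nM to 10000 nM.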

Compound 4, half-maximal inhibitory concentration: 11300 nM
The estimate for compound 4 lay 3.2-fold (0.51 log units) below the measured number; the whole stated range lies below it.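

On compound 2, putting a methoxy group in place of hydrogen on an aromatic carbon gives a 1.3-fold higher number from compound 2 to compound 4 (0.11 log units; within the scatter) in this assay, so this step cannot be told apart from ordinary repeat variation. Set beside the clear step seen earlier, this means that the same change did not carry its effect from one core to the other: the same change on two cores in this assay, a 4.4-fold lower number (0.65 log units; beyond the scatter) from compound 1 to compound 3 and a 1.3-fold higher number (0.11 log units; within the scatter) from compound 2 to compound 4, 5.7-fold (0.75 log units) apart, beyond the scatter of two such steps. These two pairs do not show what sets the size of the step, since the new methoxy group sits in different surroundings in each, and they give no general rule for methoxy groups across the series.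

On these data alone, it remains open whether an amine or a carboxylic acid in place of hydrogen on that crowded aromatic carbon of compound 2 would give a step beyond the scatter. As far as these compounds go, it is also open whether a longer chain, such as ethoxy, would follow the result for methoxy on either core.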